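Adding a Methyl to the Amine Nitrogen of Compound 3

The compounds below may be only part of what the source reports. "The series", "measured", "known", "first", "only" and "open" are said of these compounds alone.

Compound 1 `COc1ccccc1-c1cc(C2CCNC2)ccc1Cl`: 970 nM
Compound 2 `COc1ccccc1-c1cc(C2CCN(C)C2)ccc1Cl`: 1000 nM
Compound 3 `CNCc1ccc(Cl)c(-c2ccccc2OC)c1`: 420 nM

In an assay on isolated protein for binding affinity to 5-hydroxytryptamine receptor 5A (Homo sapiens) (a lower number here means a stronger inhibitor, a higher number a weaker inhibitor), compound 3 has the lowest number of the three measured compounds; the steps of a 2.3-fold lower number from compound 1 to compound 3 (0.36 log units; beyond the scatter) and a 2.4-fold lower number from compound 2 to compound 3 (0.38 log units; beyond the scatter) both lie beyond the scatter, so compound 3 stands apart as the strongest binder here.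

Compound 4 `COc1ccccc1-c1cc(CN(C)C)ccc1Cl` differs from compound 3 in one place: methyl in place of hydrogen on an amine nitrogen. One measured step is of the same kind, a methyl in place of hydrogen on an amine nitrogen, and it was a 1.0-fold higher number from compound 1 to compound 2 (0.01 log units; within the scatter), a change within the scatter. On that basis the step of a 1.0-fold higher number from compound 3 to compound 4 (0.01 log units; within the scatter) is expected to bring no change beyond the scatter. Compound 4 is therefore expected to give about 430 nM, with a range from 200 nM to 950 nM.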

Compound 4, inhibition constant: 220 nM
Compound 4: middle estimate off by 2.0-fold (0.29 log units), on the high side; the measured number falls inside the stated range.
By their numbers in this assay, from the lowest: compounds 4 and 3 (each within the scatter of the next); then compounds 1 and 2 (each within the scatter of the next).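

In this assay, the open (methylamino)methyl chain takes a second methyl on its amine nitrogen without a change beyond the scatter (a 1.9-fold lower number from compound 3 to compound 4 (0.28 log units; within the scatter)), matching what the nitrogen in the ring showed. The (dimethylamino)methyl group also stays clearly apart from the two ring-bearing compounds, with (a 4.5-fold lower number from compound 2 to compound 4 (0.66 log units; beyond the scatter)) and (a 4.4-fold lower number from compound 1 to compound 4 (0.64 log units; beyond the scatter)). No supporting data explain these differences.

Still open, as far as these compounds go, is whether this nitrogen would accept something larger than methyl, such as an ethyl or isopropyl group. A longer chain between the amine and the core is also untested in the compounds shown.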